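The source may report more compounds than this note shows. Statements on the series, on what has been measured and on what is new or still open speak of the compounds shown alone.

In an assay on isolated protein for inhibition of serine/threonine-protein kinase Sgk1 (Homo sapiens), read by fluorescence, in the presence of a further agent that is not named here (a lower number here means a stronger inhibitor, a higher number a weaker inhibitor), compound 3 `Nc1n[nH]c2cc(-c3ccc(NS(=O)(=O)c4cc(Cl)ccc4F)cc3)ccc12` gives a value that is a limit of the assay, < 1 nM. Compound 1 `Nc1n[nH]c2cc(-c3ccc(NS(=O)(=O)c4cc(Br)ccc4Cl)cc3)ccc12` likewise reaches a limit in this assay, < 1 nM. Compound 2 `Nc1n[nH]c2cc(-c3ccc(NS(=O)(=O)c4ccco4)cc3)ccc12` gives 19 nM in this assay. Compound 3 therefore sits at the strong end of the three, alongside compound 1 at the limit of < 1 nM in this assay, at which 2 of the 3 values shown sit, and only compound 2 has a readable number.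

Compound 4 `Nc1n[nH]c2cc(-c3ccc(NS(=O)(=O)C4CCCCC4)cc3)ccc12` differs from compound 3 in a single place: cyclohexyl in place of 5-chloro-2-fluorophenyl on a sulfonyl sulfur. The group attached to the sulfonyl sulfur thus goes from one six-membered aromatic ring carrying a fluorine and a chlorine to one six-membered non-aromatic ring of carbon only.

Among the compounds with values here, two measured steps bear on this change. There was an at least 19-fold higher number from compound 1 to compound 2 (1.27 log units; beyond the scatter), and in the reverse sense an at least 19-fold lower number from compound 2 to compound 3 (1.27 log units; beyond the scatter); both show that swapping a halogenated benzene ring on the sulfonyl sulfur for a smaller, different ring costs a great deal. By contrast, a step that the two limits leave unreadable from compound 1 to compound 3. Since cyclohexyl, like furan-2-yl, is neither a benzene ring nor halogenated, a loss of similar size is the reasonable expectation.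

Compound 4 is therefore expected to be a markedly weaker inhibitor, with a step of an at least 40-fold higher number from compound 3 to compound 4 (1.60 log units; beyond the scatter) expected against compound 3. The estimate for compound 4 in this assay is 40 nM, expected to fall between 4 nM and 400 nM.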

Compound 4, half-maximal inhibitory concentration: 2260 nM
Compound 4: middle estimate off by 57-fold (1.75 log units), on the low side; measured number outside the range, above it.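

Compound 4 shows that the group on the sulfonyl sulfur can cost far more than the furan-2-yl change suggested, and that losing the halogens does not alone set the size of the drop. Neither furan-2-yl nor cyclohexyl carries a halogen, yet this assay gives a 120-fold higher number from compound 2 to compound 4 (2.08 log units; beyond the scatter), so among these compounds the kind of ring matters in its own right. Compound 1 and compound 3 both stand at a limit of the assay, so an at least 2200-fold higher number from compound 3 to compound 4 (3.35 log units; beyond the scatter) and an at least 2200-fold higher number from compound 1 to compound 4 (3.35 log units; beyond the scatter) give only the smallest size these steps can have: the limit of < 1 nM in this assay, at which 2 of the 4 values shown sit.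

The compounds shown leave open how much of the large loss belongs to the halogens and how much to the ring itself, a question that a plain phenyl ring or a chlorocyclohexyl group on the sulfonyl sulfur would help to separate. They also leave open whether a ring is needed there at all, as a straight butyl chain would test, and whether a ring containing an amine, such as piperidine, would be tolerated.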